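The compounds below may be only part of what the source reports. "The series", "measured", "known", "first", "only" and "open" are said of these compounds alone.

For the measured compounds named here, compound 3 `CC(C)(N)C(=O)N[C@H](COCc1ccccc1)c1nnn(C/C=C/c2ccccc2)n1` gives 517 nM in a functional assay on H4 cells for agonist activity at growth hormone secretagogue receptor type 1 (Homo sapiens), read by FLIPR (a higher number here means that more compound is needed for the effect, a lower number that less compound is needed), the lowest of the three numbers so far: compound 2 `CC(C)(N)C(=O)N[C@H](COCc1ccccc1)c1nnn(Cc2ccc(NS(C)(=O)=O)cc2)n1` gives 986 nM, a step from compound 2 to compound 3 that is a 1.9-fold lower number from compound 2 to compound 3 (0.28 log units; within the scatter), and compound 1 `CC(C)(N)C(=O)N[C@H](COCc1ccccc1)c1nnn(Cc2ccccc2)n1` gives 1120 nM, a step from compound 1 to compound 3 that is a 2.2-fold lower number from compound 1 to compound 3 (0.34 log units; beyond the scatter). The third measured step, from compound 1 to compound 2, is a 1.1-fold lower number from compound 1 to compound 2 (0.06 log units; within the scatter).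

Compound 4 `COC(=O)C(c1ccccc1)n1nnc([C@@H](COCc2ccccc2)NC(=O)C(C)(C)N)n1` differs from compound 3 at the aromatic nitrogen: methoxycarbonyl)(benzyl in place of 3-phenylprop-2-en-1-yl on an aromatic nitrogen. Both measured steps at this nitrogen bear on it. The change from phenyl to 2-phenylethenyl on the chain carbon, a 2.2-fold lower number from compound 1 to compound 3 (0.34 log units; beyond the scatter), and the change from 4-(methanesulfonamido)phenyl to 2-phenylethenyl, a 1.9-fold lower number from compound 2 to compound 3 (0.28 log units; within the scatter), were modest. Going by the values given here, compound 4 returns to a group with the six-membered aromatic ring directly on the chain carbon, as in compound 1, with a methoxycarbonyl added on that carbon; no measured step shows what such an addition does. Compound 4 is therefore expected to give a number near that of compound 1, a step from compound 3 to compound 4 of a 1.7-fold higher number from compound 3 to compound 4 (0.24 log units; within the scatter), toward more compound needed. The estimate for compound 4 in this assay is 900 nM, between 400 nM and 2000 nM.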

Compound 4, half-maximal effective concentration: 3170 nM
For compound 4 the middle estimate is 3.5-fold (0.55 log units) below the measured one; the whole stated range lies below it.
By their numbers in this assay, from the lowest: compounds 3, 2 and 1 (each within the scatter of the next, the first and the last beyond it); then compound 4.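

In this assay, for the compounds shown here, the earlier steps at this aromatic nitrogen all led to lower numbers, whereas the change to methoxycarbonyl)(benzyl goes the other way and beyond the scatter, a 6.1-fold higher number from compound 3 to compound 4 (0.79 log units; beyond the scatter). The comparison with compound 1 isolates a single addition: with the six-membered aromatic ring and the rest of the molecule kept, a methoxycarbonyl in place of hydrogen on the saturated chain carbon gives a 2.8-fold higher number from compound 1 to compound 4 (0.45 log units; beyond the scatter), so this position responds to substitution on that carbon and not only to exchange of the group that carries the aromatic ring. Nothing available here accounts for this rise in the number.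

The compounds shown leave open whether any group on that chain carbon raises the number or whether this follows from the methoxycarbonyl itself, a question that a methyl, a hydroxymethyl, a carboxylic acid or a primary amide at the same carbon would address. They also leave open whether a methoxycarbonyl on the chain carbon of the 3-phenylprop-2-en-1-yl group of compound 3 would produce a step of similar size.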